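This account rests on a few compounds, and the source may have more. Where it says the series, first, only, none or still open, it means among the compounds named here.

Two open-chain amides, compound 1 `CC(O)(COc1cccc(S(F)(F)(F)(F)F)c1)C(=O)Nc1ccc(C#N)cc1C(F)(F)F` and compound 2 `CC(O)(COc1cccc(S(F)(F)(F)(F)F)c1)C(=O)Nc1ccc([N+](=O)[O-])cc1C(F)(F)F`, share a core whose difference from that of the cyclic thiourea compound 3 `CC1(C)C(=O)N(c2ccc([N+](=O)[O-])c(C(F)(F)F)c2)C(=S)N1c1cccc(S(F)(F)(F)(F)F)c1` is not broken down here. In a functional assay on CWR22R cells (Homo sapiens) for antiproliferative activity, read by propidium iodide staining, with a stated time of 96 h (on this read-out higher numbers stand for weaker inhibition and lower numbers for stronger inhibition), compound 1 gives 11600 nM, compound 2 gives 15500 nM, and compound 3 gives 100000 nM, the highest of the three numbers. The change from compound 2 to compound 1 is cyano in place of nitro on an aromatic carbon, and it made a 1.3-fold lower number from compound 2 to compound 1 (0.13 log units; within the scatter). Compound 4 `CC1(C)C(=O)N(c2ccc(C#N)c(C(F)(F)F)c2)C(=S)N1c1cccc(S(F)(F)(F)(F)F)c1` carries the same kind of change on the core of compound 3, namely (cyano in place of nitro on an aromatic carbon); here the cyano sits ortho to the trifluoromethyl group, whereas in compound 1 it sits meta to it. For compound 4 in this assay a step of a 1.3-fold lower number from compound 3 to compound 4 (0.10 log units; within the scatter) is expected, resting on the small step seen from compound 2 to compound 1 a 1.3-fold lower number from compound 2 to compound 1 (0.13 log units; within the scatter). Compound 4 is therefore estimated at 80000 nM, between 35000 nM and 180000 nM.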

Compound 4, half-maximal inhibitory concentration: 100000 nM
Beside the measured number, compound 4's estimate is 1.3-fold (0.10 log units) below it, and the stated range covers the measured number.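

In this assay, cyano in place of nitro on an aromatic carbon of the second core gave no change at the digits printed from compound 3 to compound 4 (within the scatter). Set beside the earlier step, this agrees with it: the same change on two cores in this assay, a 1.3-fold lower number (0.13 log units; within the scatter) from compound 2 to compound 1 and no change at the digits printed (within the scatter) from compound 3 to compound 4, 1.3-fold (0.13 log units) apart, within the scatter of two such steps. For the compounds shown here, the change can thus be carried between these two cores as a step within the scatter, but this rests on only two pairs and does not show that it would hold on any other core, nor that the change does anything measurable on either of these two.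

The compounds shown leave open how other groups on that aromatic carbon, such as an amine or a carboxylic acid, would compare with cyano and nitro. They also leave open whether a longer chain on the shared cores would alter the step.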